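The compounds below may be only part of what the source reports. "The series", "measured", "known", "first", "only" and "open" are said of these compounds alone.

Compound 1 `CCC(=O)N1N=C(c2ccc(F)cc2)CC1c1ccccc1` serves as the reference point of this small series. In an assay on isolated protein for inhibition of Amine oxidase [flavin-containing] B (Bos taurus) (a lower number here means a stronger inhibitor, a higher number a weaker inhibitor), compound 1 gives 200 nM. Compound 2 `CCC(=O)N1N=C(c2ccc(F)cc2)CC1c1ccc(Cl)cc1` differs from it in one place, (chloro in place of hydrogen on an aromatic carbon), and in this assay compound 2 gives 6310 nM, so that the change produced a 32-fold higher number from compound 1 to compound 2 (1.50 log units; beyond the scatter). Compound 3 `CCC(=O)N1N=C(c2ccc(OC)cc2)CC1c1ccccc1` carries a different core; the two cores differ as methoxy in place of fluoro on an aromatic carbon. In this assay compound 3 gives 25100 nM, which corresponds to a 130-fold higher number from compound 1 to compound 3 (2.10 log units; beyond the scatter). Compound 3 thus stands at the highest number of the three measured compounds, with compound 2 nearest and compound 1 furthest from it.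

Compound 4 `CCC(=O)N1N=C(c2ccc(OC)cc2)CC1c1ccc(Cl)cc1` has not yet been measured. It differs from compound 3 as chloro in place of hydrogen on an aromatic carbon, the same change that separates compound 2 from compound 1, placed on the same kind of ring and at the same place relative to the large group. Because the first occurrence of this change gave a 32-fold higher number from compound 1 to compound 2 (1.50 log units; beyond the scatter), the step from compound 3 to compound 4 is expected to be a 4.0-fold higher number from compound 3 to compound 4 (0.60 log units; beyond the scatter), although with compound 3 already at a high number the outcome may be limited by the range of the assay. On that basis compound 4 is estimated at 100000 nM in this assay, expected to fall between 20000 nM and 500000 nM.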

Compound 4, half-maximal inhibitory concentration: 851 nM
Beside the measured number, compound 4's estimate is 120-fold (2.07 log units) above it, and the stated range ends above it.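

In this assay, the step from phenyl to 4-chlorophenyl gives a 29-fold lower number from compound 3 to compound 4 (1.47 log units; beyond the scatter), so on the core of compound 3 the change runs in the opposite direction to its effect on the core of compound 1: the same change on two cores in this assay, a 32-fold higher number (1.50 log units; beyond the scatter) from compound 1 to compound 2 and a 29-fold lower number (1.47 log units; beyond the scatter) from compound 3 to compound 4, 930-fold (2.97 log units) apart, beyond the scatter of two such steps

Read the other way round the same four compounds, methoxy in place of fluoro gives a 7.4-fold lower number from compound 2 to compound 4 (0.87 log units; beyond the scatter), and this change too reverses direction once the chloro is present: the same change on two cores in this assay, a 130-fold higher number (2.10 log units; beyond the scatter) from compound 1 to compound 3 and a 7.4-fold lower number (0.87 log units; beyond the scatter) from compound 2 to compound 4, 930-fold (2.97 log units) apart, beyond the scatter of two such steps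

This shows that neither change carries over from one core to the other in this series, and that the effect of each depends on what stands elsewhere in the molecule, but both comparisons rest on compounds 1, 2, 3 and 4 alone, so they form a single observation and do not show how general the reversal is or what lies behind it.

The compounds shown leave open whether a bromo or a methyl group in place of the chloro, or an ethoxy group in place of the methoxy, would show the same reversal. They also leave open whether it would persist with a longer chain in place of the acyl chain that all four compounds share.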